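Replacing chloro with amino in the antiproliferative series

A few compounds are considered here, and "the series" means these few. Any claim that something is new, unique, unknown or untested is made for them only; others in the source may bear on it.

Values in a functional assay on HCT-116 cells (Homo sapiens) for antiproliferative activity, read by MTT assay, with a stated time of 48 h (a lower number here means a stronger inhibitor, a higher number a weaker inhibitor), so far:
compound 1 `CCC(CCO)n1cnc2c(Cl)ncnc21` gives > 50000 nM as a limit
compound 2 `CCCCCCC(CCO)n1cnc2c(Cl)ncnc21` gives 11900 nM as a number

Going by the values given here, compound 2 at 11900 nM holds the only true number. For compound 1 there is a limit only, (the limit of > 50000 nM in this assay, at which 1 of the 2 values shown sits), and not a number.

The next compound is compound 3 `CCCCCCC(CCO)n1cnc2c(N)ncnc21`, which keeps the butyl-extended chain of compound 2 and changes the core: amino in place of chloro on an aromatic carbon. This is amino in place of chloro on an aromatic carbon, next to the ring nitrogen.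

Among the compounds with values here, the sole measured step, an at least 4.2-fold lower number from compound 1 to compound 2 (0.62 log units; beyond the scatter), was butyl in place of hydrogen on a saturated chain carbon, so it lies elsewhere in the structure. Within the data shown here, no measured step touches this aromatic carbon, which leaves the size of the change poorly defined. Going by these compounds, a move towards a higher number in this assay is tentatively expected, of roughly the size of that one step, and the opposite direction remains open.

The expected change is a 1.8-fold higher number from compound 2 to compound 3 (0.27 log units; within the scatter). For compound 3 the estimate is 22000 nM, with an expected range from 7000 nM to 50000 nM as the outcome.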

Compound 3, half-maximal inhibitory concentration: > 50000 nM
Compound 3 was reported as a limit; the forecaster's own chance of this, stated with the estimate: 25%; middle value at least 2.2-fold (0.35 log units) away from the limit.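

At the aromatic carbon next to the ring nitrogen, the first measured change is amino in place of chloro, which gives an at least 4.2-fold higher number from compound 2 to compound 3 (0.62 log units; beyond the scatter) in this assay. Compound 3 gives > 50000 nM, which is a limit and not a number. The butyl extension alone therefore does not secure a number in this assay: compound 2, with both butyl and chloro, is the only compound of the three with a true value, and removing either butyl or chloro from it returns the read-out to the limit: the limit of > 50000 nM in this assay, at which 2 of the 3 values shown sit.

How much of this step is hidden past the limit cannot be read from the compounds shown, so the comparison with the butyl step remains a matter of lower bounds only. Whether bromo or methylamino on this aromatic carbon would give a true number is open, as is whether a chain longer than the butyl-extended one would bring a number back with amino in place.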